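The source may hold more compounds than are shown below. What is called first, only, known or untested is meant among the compounds shown, and "the series" means these compounds.

Measured compounds:
compound 1 `O=C(/C=C/c1ccc(CN2C(=O)/C(=C3\Nc4ccccc4\C3=N/O)c3cc(F)ccc32)cc1)NO`: 50 nM
compound 2 `O=C(/C=C/c1ccc(CN2C(=O)/C(=C3\Nc4ccccc4\C3=N/O)c3cccc(Cl)c32)cc1)NO`: 90 nM
compound 3 `O=C(NO)c1ccc(CN2C(=O)/C(=C3\Nc4ccccc4\C3=N/O)c3cccc(Cl)c32)cc1`: 60 nM

In a functional assay on PC-3 cells (Homo sapiens) for cytotoxicity, read by colorimetric assay (on this read-out higher numbers stand for weaker inhibition and lower numbers for stronger inhibition), compound 2 stands at the highest of the three numbers, yet compound 3 and compound 1 both lie within the usual scatter of it. Among the compounds with values here, the one single-point step measured so far is a 1.5-fold lower number from compound 2 to compound 3 (0.18 log units; within the scatter), and it concerns the hydroxycarbamoyl side of the molecule, not the halogenated ring.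

Compound 4 `O=C(/C=C/c1ccc(CN2C(=O)/C(=C3\Nc4ccccc4\C3=N/O)c3ccccc32)cc1)NO` differs from compound 2 by hydrogen in place of chloro on an aromatic carbon. Within the data shown here, no measured pair isolates the chloro itself, so nothing in the data speaks directly to this step. Compound 1 carries a fluoro in another place and its number sits within the scatter of compound 2, which is the only hint that the ring substituent is not decisive here.

Compound 4 is therefore expected to give 70 nM in this assay, with a range from 30 nM to 170 nM. That estimate means a 1.3-fold lower number from compound 2 to compound 4 (0.11 log units; within the scatter), a step expected to remain within the scatter.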

Compound 4, half-maximal inhibitory concentration: 50 nM
Estimate against measurement, compound 4: 1.4-fold (0.15 log units) above; low and high end bracket the measured number.
By their numbers in this assay, from the lowest: compounds 1, 4, 3 and 2 (each within the scatter of the next).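

Hydrogen in place of chloro on an aromatic carbon is now isolated as a single change: in this assay the step is a 1.8-fold lower number from compound 2 to compound 4 (0.26 log units; within the scatter), so this position, ortho to a fused ring and meta to a fused ring, tolerates either group within the scatter. Within the data shown here, the fluoro in its other place is also isolated for the first time, with no change at the digits printed from compound 1 to compound 4 (within the scatter), so neither halogen is needed for a number in this range. No measurement bearing on why these steps stay so small is available.

From the compounds shown here alone, only chloro, fluoro and hydrogen appear on this ring, so it remains open whether a methoxy, an amine or a carboxylic acid there would step beyond the scatter. Also open, going by these compounds, is whether hydroxycarbamoyl in place of 2-(hydroxycarbamoyl)ethenyl reads the same on a core without the chloro.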